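The compounds below may be only part of what the source reports. "The series", "measured", "known", "first", "only" and "open" are said of these compounds alone.

Compound 1, `CC1=C(C(=O)Nc2ccc(Br)cc2)C(c2ccc(Cl)cc2Cl)N=C(SCc2ccccc2Cl)N1`: in a functional assay on the whole organism (artery, strain albino) with Rattus norvegicus as the target, with a stated time of 60 min, at a dose of 10 mg/kg by the oral route (a higher number here means more inhibition at the dose given (going by the name of the read-out), a lower number less inhibition), compound 1 gives 11.8%.
Compound 2, `CC1=C(C(=O)Nc2ccc(Br)cc2)C(c2ccc(Cl)cc2Cl)N=C(SCc2cccc(Cl)c2)N1`: in this assay compound 2 gives 6.2%.
Compound 3, `CC1=C(C(=O)Nc2ccc([N+](=O)[O-])cc2)C(c2cccc([N+](=O)[O-])c2)N=C(SCc2ccccc2Cl)N1`: in this assay compound 3 gives 6.7%.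

All three measured compounds return small inhibition numbers in this assay, and no two of them are separated by more than the usual scatter, so none can be said to give the highest or the lowest number. Going by the values given here, the one single-point change that is measured is 3-chlorophenyl in place of 2-chlorophenyl on a saturated chain carbon bound to a sulfur, and that change gave a number 5.6 percentage points lower from compound 1 to compound 2 (within the scatter).

Compound 4, `CC1=C(C(=O)Nc2ccc([N+](=O)[O-])cc2)C(c2cccc([N+](=O)[O-])c2)N=C(SCc2cccc(Cl)c2)N1`, has not yet been measured. It differs from compound 3 by 3-chlorophenyl in place of 2-chlorophenyl on a saturated chain carbon bound to a sulfur, the same kind of change seen between compound 1 and compound 2, made at the same place. How the core of compound 3 differs from the core of compound 1 is not broken down here.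

Since compound 1 and compound 2 showed only a small step with this change, a similarly small step is expected from compound 3, namely a number 3.7 percentage points lower from compound 3 to compound 4 (within the scatter). Compound 4 is therefore estimated at 3%, with a likely range from -8% to 14%.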

Compound 4, a percentage reported as inhibition, in the whole organism at one dose (the size of the read-out at that dose, not a potency): 8.2%
The estimate for compound 4 lay 5.2 percentage points below the measured number; measured number inside the range.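

On the core of compound 3, 3-chlorophenyl in place of 2-chlorophenyl on a saturated chain carbon bound to a sulfur gave a number 1.5 percentage points higher from compound 3 to compound 4 (within the scatter) in this assay. Set beside the step on the core of compound 1, the change shows no measurable difference between the two cores: the same change on two cores in this assay, a number 5.6 percentage points lower (within the scatter) from compound 1 to compound 2 and a number 1.5 percentage points higher (within the scatter) from compound 3 to compound 4, 7.1 percentage points apart, within the scatter of two such steps. This shows that the change left the number within the scatter on both cores, but it does not establish a shared size or direction for the step, and neither core shows what the change would do to a compound with a clearly larger inhibition number.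

All the compounds shown carry a chlorobenzyl group on the sulfur, so it remains open how the number would respond to an amine or a carboxylic acid in place of that chlorine, or to a plain ethyl chain in place of the whole benzyl group. From the compounds shown here alone, it also remains open whether any such compound would stand beyond the scatter from these four.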